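The compounds below may be only part of what the source reports. "The series", "measured", "known", "first", "only" and "open" are said of these compounds alone.

Compound 1 `C=CC1=C(C(=O)Nc2ccccc2OC)C(c2ccc(F)cc2)OC1` — > 100000 nM
Compound 2 `C=CC1=C(C(=O)Nc2ccccc2OC)C(c2ccc(Cl)c(Cl)c2)OC1` — > 100000 nM

In a functional assay on HeLa cells (Homo sapiens) for cytotoxicity, read by MTT assay, with a stated time of 24 h (a lower number here means a stronger inhibitor, a higher number a weaker inhibitor), compound 1 gives only a limit, > 100000 nM. Compound 2 likewise gives a limit in this assay, > 100000 nM. Within the data shown here, the single step between measured compounds, a step that the two limits leave unreadable from compound 1 to compound 2, cannot be read because the limit of > 100000 nM in this assay, at which 2 of the 2 values shown sit, places both values at that limit, so compound 1 stands on a limit with no readable neighbour. Compound 3 `C=CC1=C(C(=O)NC2CCCCC2)C(c2ccc(F)cc2)OC1` has not yet been measured; it differs from compound 1 by cyclohexyl in place of 2-methoxyphenyl on an amide-type nitrogen. Among the measured compounds shown here, no measured step touches the amide-type nitrogen, so this change has no comparison among the measured compounds, and what is known of compound 1 is only its limit. Compound 3 is therefore expected to give 150000 nM, in a range from 30000 nM to 1000000 nM, most likely again as a limit rather than a number. The step this means, a step that the limit leaves unreadable from compound 1 to compound 3, is expected to be no more than the scatter.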

Compound 3, half-maximal inhibitory concentration: > 100000 nM
Compound 3: only a limit was reported; the forecaster's own chance of this, stated with the estimate: 80%; the middle value does not contradict the limit.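

In this assay compound 3 gives only a limit, > 100000 nM. Compound 1 also stands on a limit, so no step from compound 1 to compound 3 can be read: the limit of > 100000 nM in this assay, at which 3 of the 3 values shown sit. The compounds shown leave open whether any change on the amide-type nitrogen or the saturated ring carbon gives a readable value in this assay.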